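Swapping a Hydroxymethyl Phenyl for a Methoxyphenyl

The source may hold more compounds than are shown below. What is called first, only, known or untested is meant among the compounds shown, and "the series" means these compounds.

Measured so far:
compound 1 `CC[C@@H](Nc1c(C#N)c(-c2ccc(-c3cccc(CO)c3)cc2)nc2cnccc12)C(N)=O`: 2
compound 2 `CCOc1ccccc1-c1ccc(-c2nc3cnccc3c(NC(CC)CNS(=O)(=O)C3CC3)c2C#N)cc1`: 3.6

Of the compounds shown here, two sharing one core have been measured in a physicochemical assay for lipophilicity, read by HPLC, at pH 7.5; on this read-out higher numbers stand for higher lipophilicity and lower numbers for lower lipophilicity. Compound 1 gives 2, the lowest of the two numbers. The nearest value belongs to compound 2, which gives 3.6, a gap that lies beyond the usual scatter. Compound 2 differs from compound 1 in more than one place, so its distance tells nothing about any single change; it only shows that a molecule on this core carrying an alkoxy-bearing ring can stand well above compound 1.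

Compound 3 `CC[C@@H](Nc1c(C#N)c(-c2ccc(-c3ccccc3OC)cc2)nc2cnccc12)C(N)=O` has not yet been measured in this assay. It differs from compound 1 at one spot: 2-methoxyphenyl in place of 3-(hydroxymethyl)phenyl on an aromatic carbon. The group that leaves carries a hydrogen-bond donor, the group that enters carries none.

Because compound 2 gives 3.6 while compound 1 gives 2, a rise is expected rather than a fall, though a smaller one than that whole gap. The estimated step is a number 0.70 log units higher from compound 1 to compound 3 (beyond the scatter). Compound 3 is expected to give about 2.7, within 2.2 to 3.2.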

Compound 3, distribution coefficient: 2.7
The estimate for compound 3 equals the measured number at the digits printed, within the range that was stated.
By their numbers in this assay, from the lowest: compound 1; then compound 3; then compound 2.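

For the compounds shown here, this is the first comparison in the set that changes only one place, so it can be read directly, unlike the gap to compound 2. In this assay, putting 2-methoxyphenyl in place of 3-(hydroxymethyl)phenyl, on an aromatic carbon para to a large group, gives a number 0.70 log units higher from compound 1 to compound 3 (beyond the scatter), so this position does respond to the choice of group on the outer ring. Both groups have the same count of heavy atoms and the same hydrogen-bond acceptor count, yet the number moves when the hydrogen-bond donor goes and the oxygen-bearing group sits elsewhere on the ring, and nothing measured here explains the step.

On these data alone, those two differences arrive together, so it stays open which of them carries the step; a ring with methoxy where compound 1 has hydroxymethyl, or with hydroxymethyl where compound 3 has methoxy, would separate them. As far as these compounds go, it is also open how this read-out would respond at the same spot to a ring bearing an amine or a carboxylic acid.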